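This account rests on a few compounds, and the source may have more. Where it says the series, first, only, none or still open, it means among the compounds named here.

Compound 1 (`COc1cc(O)c(C(C)=O)cc1Br`) in a functional assay, with a stated time of 10 min (a higher number here means a weaker inhibitor, a lower number a stronger inhibitor), gives 3000000 nM
Compound 2 (`CCCCCCOc1cc(OC)c(Br)cc1C(C)=O`) gives 53100000 nM
Compound 3 (`CCCCCCCCCCCCCCOc1cc(OC)c(Br)cc1C(C)=O`) has no measurement yet

Compound 2 holds the higher of the two numbers. The change to compound 3 (octyl in place of hydrogen on a saturated chain carbon, six bonds along the chain from an oxygen on an aromatic ring) is octyl in place of hydrogen on a saturated chain carbon, six bonds along the chain from an oxygen on an aromatic ring. For the measured compounds named here, only one measured step bears on this, hexyl in place of hydrogen on an oxygen on an aromatic ring, which is large and beyond the scatter. On that step alone (an 18-fold higher number from compound 1 to compound 2 (1.25 log units; beyond the scatter)) a further, smaller rise in this assay is expected. The expected step (a 2.8-fold higher number from compound 2 to compound 3 (0.45 log units; beyond the scatter)) rests on thin evidence. Compound 3 is estimated at 150000000 nM within a range from 30000000 nM to 600000000 nM for now.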

Compound 3, half-maximal inhibitory concentration: 13200000 nM
Compound 3: the middle estimate sits 11-fold (1.06 log units) above what was measured, and the stated range ends above it.
By their numbers in this assay, from the lowest: compound 1; then compound 3; then compound 2.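

On this chain, adding octyl at the far end gives a 4.0-fold lower number from compound 2 to compound 3 (0.60 log units; beyond the scatter) in this assay, so the rise seen when hexyl first entered on the oxygen does not continue. Across compound 1, compound 2 and compound 3, the number therefore does not move in one direction as the chain grows, although compound 3 still reads higher than compound 1. No available evidence bears on this reversal.

Still open, from the compounds shown here alone, is how a butyl chain, a longer chain, or a chain ending in an amine or a carboxylic acid would read at this oxygen.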